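Aryl amine variation on the shared core

This account rests on a few compounds, and the source may have more. Where it says the series, first, only, none or still open, it means among the compounds named here.

In a functional assay on SMMC-7721 cells (Homo sapiens) for inhibition, read by MTT assay, with a stated time of 48 h (a lower number here means a stronger inhibitor, a higher number a weaker inhibitor), compound 1 `CN(c1ncccc1CNc1nc(Nc2ccc3c(c2)CC(=O)N3)nc2[nH]cc(F)c12)S(C)(=O)=O` gives 73200 nM. Compound 2 `CN(c1ncccc1CNc1nc(Nc2cccc(C#N)c2)nc2[nH]cc(F)c12)S(C)(=O)=O` reaches only the limit of > 100000 nM in this assay. Compound 3 `COc1ccc(Nc2nc(NCc3cccnc3N(C)S(C)(=O)=O)c3c(F)c[nH]c3n2)cc1OC` gives 54800 nM in this assay. Compound 3 and compound 1 differ by a 1.3-fold lower number from compound 1 to compound 3 (0.13 log units; within the scatter), so the two sit within the scatter of each other; the move from compound 2 is an at least 1.8-fold lower number from compound 2 to compound 3 (0.26 log units; that floor lies within the scatter), a floor set by the limit (the limit of > 100000 nM in this assay, at which 1 of the 3 values shown sits). Compound 4 `COc1cccc(Nc2nc(NCc3cccnc3N(C)S(C)(=O)=O)c3c(F)c[nH]c3n2)c1C` carries 3-methoxy-2-methylphenyl in place of 3,4-dimethoxyphenyl on a nitrogen on an aromatic ring. For the measured compounds named here, the steps that bear on this are the aryl swaps on the same nitrogen, a 1.3-fold lower number from compound 1 to compound 3 (0.13 log units; within the scatter) and an at least 1.8-fold lower number from compound 2 to compound 3 (0.26 log units; that floor lies within the scatter), neither of which moved this assay beyond the scatter; the step from compound 1 to compound 2, an at least 1.3-fold higher number from compound 1 to compound 2 (0.13 log units; that floor lies within the scatter), also stayed within it. A further exchange of one methoxy for a methyl on that aryl is therefore expected to give no step beyond the scatter in this assay. Compound 4 is expected at 55000 nM, with a range from 25000 nM to 100000 nM. The step this estimate implies is a 1.0-fold higher number from compound 3 to compound 4 (0.00 log units; within the scatter).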

Compound 4, half-maximal inhibitory concentration: > 100000 nM
Compound 4: only a limit was reported; the forecaster's own chance of this, stated with the estimate: 25%; at least 1.8-fold (0.25 log units) between middle value and limit.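

The reading for compound 4 is a limit and not a number, and compound 2 sits at that same limit: the limit of > 100000 nM in this assay, at which 2 of the 4 values shown sit. On these data alone, the exchange on this nitrogen reads as an at least 1.8-fold higher number from compound 3 to compound 4 (0.26 log units; that floor lies within the scatter), and the wider swap of the aryl group reads as an at least 1.3-fold higher number from compound 1 to compound 4 (0.13 log units; that floor lies within the scatter); both floors lie within the scatter, so the 3-methoxy-2-methylphenyl group adds no reading below the limit, and the true size of either step remains unknown. The step between the two compounds at the limit cannot be read.

The compounds shown leave open whether any group on this nitrogen can move this assay clearly beyond the scatter. An aryl group carrying an amine or a carboxylic acid, or a longer chain in place of the aryl ring, would test this.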